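The source may hold more compounds than are shown below. What is called first, only, known or untested is meant among the compounds shown, and "the series" means these compounds.

Of the compounds shown here, three sharing one core have been measured in a functional assay on B16 cells (Mus musculus) for inhibition; a higher number here means a weaker inhibitor, a lower number a stronger inhibitor. Compound 1 `Cc1cccc(/C=N/NC(N)=S)c1` gives 2800 nM. Compound 2 `Cc1ccccc1/C=N/NC(N)=S` gives 3400 nM. Compound 3 `CCc1ccccc1/C=N/NC(N)=S` gives 2700 nM, which is the lowest of the three numbers shown, but the other two sit within the usual scatter of it, so no real order can be read from them. The only step between two of these compounds that differ in a single place is a 1.3-fold lower number from compound 2 to compound 3 (0.10 log units; within the scatter), a lengthening of the group that sits on the ring, and it produced no change beyond the scatter.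

Compound 4 `NC(=S)N/N=C/c1ccccc1Cl` has not yet been measured in this assay. It differs from compound 3 by chloro in place of ethyl on an aromatic carbon. Among the measured compounds shown here, the one measured step that touches the same spot on the ring, the one from compound 2 to compound 3, was within the scatter; there is no measured step in which a chlorine takes the place of a carbon group, so nothing in the data points to a move in either direction. The expectation for compound 4 is therefore a number close to that of compound 3, a step of about a 1.1-fold higher number from compound 3 to compound 4 (0.05 log units; within the scatter), within the scatter. On that basis compound 4 is estimated at 3000 nM, with a range from 1200 nM to 7500 nM.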

Compound 4, half-maximal inhibitory concentration: 1400 nM
The estimate for compound 4 lay 2.1-fold (0.33 log units) above the measured number; low and high end bracket the measured number.
By their numbers in this assay, from the lowest: compounds 4, 3, 1 and 2 (each within the scatter of the next, the first and the last beyond it).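

Among the compounds shown here, at this place on the ring, ortho to a group of 6 heavy atoms, the earlier compounds carried only methyl or ethyl, and the one step between them stayed within the scatter. In this assay, chloro gives a 2.4-fold lower number from compound 2 to compound 4 (0.39 log units; beyond the scatter), a modest change but the first step among these compounds to clear the scatter, whereas a 1.9-fold lower number from compound 3 to compound 4 (0.29 log units; within the scatter) does not clear it, so chloro can be told apart from methyl here but not from ethyl. None of the information available accounts for the difference between chloro and methyl at this place.

Still open, on these data alone, is whether this step is particular to chloro: fluoro, bromo, methoxy or an amine at the same place would show whether other groups give numbers that stay apart from that of compound 2 or fall within its scatter. Also open, as far as these compounds go, is whether chloro would give a number apart from that of compound 1 if it stood on the ring carbon that carries the methyl group of compound 1.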